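The source may hold more compounds than are shown below. What is called first, only, known or untested is meant among the compounds shown, and "the series" means these compounds.

Compound 2 `O=C(CN1CCNCC1)N1CCC(NS(=O)(=O)c2cc(S(=O)(=O)c3ccccc3)ccc2C(F)(F)F)CC1` and compound 1 `O=C(CN1CCCC1)N1CCC(NS(=O)(=O)c2cc(S(=O)(=O)c3ccccc3)ccc2C(F)(F)F)CC1` share the same sulfonamide core and differ only in the amine on the acetyl chain. Going by the values given here, in an assay on isolated protein for binding affinity to secreted frizzled-related protein 1 (Homo sapiens), read by fluorescence (a lower number here means a stronger inhibitor, a higher number a weaker inhibitor), compound 1 gives 110 nM, and in this assay compound 2 gives 140 nM; these are the only two numbers so far, and the two values lie within the scatter of each other, with a 1.3-fold higher number from compound 1 to compound 2 (0.10 log units; within the scatter), so no order can be read between them.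

Compound 3 `CC(C)(C)OC(=O)N1CCC[C@H]1C(=O)N1CCC(NS(=O)(=O)c2cc(S(=O)(=O)c3ccccc3)ccc2C(F)(F)F)CC1` is not yet measured in this assay. The change from compound 2 is 1-(tert-butoxycarbonyl)pyrrolidin-2-yl in place of (piperazin-1-yl)methyl on a carbonyl carbon. Among the compounds with values here, the one measured step that bears on it, the change from compound 1 to compound 2, swapped one saturated amine ring for another at the same place and gave a 1.3-fold higher number from compound 1 to compound 2 (0.10 log units; within the scatter), a step within the scatter. The present change is larger: the carbonyl now carries a ring directly, the donor is lost and a carbamate enters. Within the data shown here, with only one within-scatter step as a guide, a modest weakening is expected for compound 3, a step of a 1.6-fold higher number from compound 2 to compound 3 (0.20 log units; within the scatter), and the estimated value for compound 3 in this assay is 220 nM, in a range from 70 nM to 700 nM.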

Compound 3, half-maximal inhibitory concentration: 60 nM
Compound 3: the middle estimate sits 3.7-fold (0.56 log units) above what was measured, outside the stated range (below it).
By their numbers in this assay, from the lowest: compounds 3, 1 and 2 (each within the scatter of the next, the first and the last beyond it).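

In this assay, going by these compounds alone, the place on a carbonyl carbon takes a much larger change than the swap of one saturated amine ring for another, and the number still does not rise: 1-(tert-butoxycarbonyl)pyrrolidin-2-yl, with 12 heavy atoms, 0 hydrogen-bond donors and 1 defined stereocentre, in place of (piperazin-1-yl)methyl gives (a 2.3-fold lower number from compound 2 to compound 3 (0.37 log units; beyond the scatter)), the first step beyond the scatter. Measured against (pyrrolidin-1-yl)methyl, the same group gives (a 1.8-fold lower number from compound 1 to compound 3 (0.26 log units; within the scatter)), so compound 3 and compound 1 cannot be ordered, and the difference holds against compound 2 only. No measurement at hand accounts for the step to compound 3.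

As far as these compounds go, it remains open which part of the entering group goes with the lower number: the carbamate, the ring carried directly on the carbonyl carbon, or the defined stereocentre. A pyrrolidin-2-yl group with a free ring amine, or with a simple acetyl in place of tert-butoxycarbonyl, would separate these parts, as would the opposite stereoisomer of compound 3.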